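Nitro for methoxy on the benzylidene arm

This account rests on a few compounds, and the source may have more. Where it says the series, first, only, none or still open, it means among the compounds named here.

Measured in a functional assay on A549 cells (Homo sapiens) for antiproliferative activity, read by MTT assay; on this read-out higher numbers stand for weaker inhibition and lower numbers for stronger inhibition:
- compound 1, `O=C1N=C(N2CCC[C@H]2C(=O)Nc2ccc3ncnc(Nc4cccc(Cl)c4)c3c2)S/C1=C/c1ccc(-c2ccccc2)cc1`: 24200 nM
- compound 2, `O=C1N=C(N2CCC[C@H]2C(=O)Nc2ccc3ncnc(Nc4cccc(Cl)c4)c3c2)S/C1=C/c1cccnc1Cl`: 10800 nM
- compound 3, `COc1ccccc1/C=C1/SC(N2CCC[C@H]2C(=O)Nc2ccc3ncnc(Nc4cccc(Cl)c4)c3c2)=NC1=O`: only a limit, > 50000 nM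

Compound 3 stands at the weak end of this set: its value is a limit of this assay, not a number, and both measured steps to it run the same way, an at least 2.0-fold higher number from compound 1 to compound 3 (0.31 log units; beyond the scatter) and an at least 4.6-fold higher number from compound 2 to compound 3 (0.66 log units; beyond the scatter). Compound 2 gave the lowest number, a 2.2-fold lower number from compound 1 to compound 2 (0.35 log units; beyond the scatter).

Compound 4, `O=C1N=C(N2CCC[C@H]2C(=O)Nc2ccc3ncnc(Nc4cccc(Cl)c4)c3c2)S/C1=C/c1ccccc1[N+](=O)[O-]`, differs from compound 3 by nitro in place of methoxy on an aromatic carbon. Among the compounds with values here, no measured step swaps one substituent for another on this ring while keeping the ring; the steps seen exchange whole aryl groups and range from modest to at least modest. They therefore give no direction for the nitro change. Since compound 3 sits at the limit of > 50000 nM in this assay, at which 1 of the 3 values shown sits, the step from compound 3 to compound 4 is estimated as a number no higher from compound 3 to compound 4 (the limit leaves the size open), with a real chance that compound 4 again reports only a limit. Compound 4 is expected near 50000 nM, between 15000 nM and 150000 nM.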

Compound 4, half-maximal inhibitory concentration: > 50000 nM
Compound 4 ended at the assay's limit; the forecaster's own chance of this, stated with the estimate: 55%; the middle value lies on the limit itself.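

In this assay compound 4 gives > 50000 nM, which is a limit of the assay and not a number. The 2-nitrophenyl arm thus joins the 2-methoxyphenyl arm of compound 3 at the same limit, the step between these two cannot be read, and the set now shows this clustering at the weak end: the limit of > 50000 nM in this assay, at which 2 of the 4 values shown sit. Against the arms with measured numbers, the 2-nitrophenyl arm sits on the weak side, with an at least 4.6-fold higher number from compound 2 to compound 4 (0.66 log units; beyond the scatter) and an at least 2.0-fold higher number from compound 1 to compound 4 (0.31 log units; beyond the scatter), though the 2-chloropyridin-3-yl arm of compound 2 goes against any rule that a group at this place on the ring costs a readable number.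

Going by these compounds, how far compound 3 and compound 4 lie beyond the limit stays open, so no order of nitro and methoxy can be drawn. On these data alone, whether an amine or a hydroxyl on the same ring carbon would return a measurable number also stays open.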